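The source may report more compounds than this note shows. Statements on the series, on what has been measured and on what is new or still open speak of the compounds shown alone.

The measured compounds and their results in a functional assay on HEK293 cells for agonist activity at G-protein coupled receptor 39 (Homo sapiens), read by scintillation proximity assay and inositol phosphate accumulation, with a stated time of 75 min, in the presence of a further agent that is not named here; a higher number here means that more compound is needed for the effect, a lower number that less compound is needed:
compound 1 `CCCCCCCCOC1CC(=O)Nc2c1c(C)nn2-c1ncnc2nc[nH]c12` gives 8 nM;
compound 2 `Cc1nn(-c2ncnc3nc[nH]c23)c2c1C(C(=O)N(C)c1ccccc1)CC(=O)N2` gives 32 nM;
compound 3 `COc1ccc(CCOC2CC(=O)Nc3c2c(C)nn3-c2ncnc3nc[nH]c23)cc1` gives 2 nM.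

Compound 3 holds the lowest number of the three. Its nearest neighbour is compound 1, separated from it by the step of a 4.0-fold lower number from compound 1 to compound 3 (0.60 log units; beyond the scatter); compound 2 lies furthest away, its number higher still.

Compound 4 `Cc1nn(-c2ncnc3nc[nH]c23)c2c1C(OCC(C)C)CC(=O)N2` differs from compound 3 in one place: isopropyl in place of 4-methoxybenzyl on a saturated chain carbon bound to an oxygen on a saturated carbon. For the measured compounds named here, the step that bears most directly on this change is the one from compound 1 to compound 3, a 4.0-fold lower number from compound 1 to compound 3 (0.60 log units; beyond the scatter), which introduced the 4-methoxyphenyl at the end of the chain and brought the number down modestly. Compound 4 loses that group again, and its chain is also shorter than the octyl of compound 1, for which no comparison is available. The other step, a 4.0-fold higher number from compound 1 to compound 2 (0.60 log units; beyond the scatter), exchanged the whole ether substituent on the same saturated ring carbon and is less informative here. A modest rise is therefore expected, to around the level of compound 1 or somewhat above it.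

Compound 4 is expected to give 15 nM in this assay, within a range of 4 nM to 60 nM. That corresponds to an expected step of a 7.5-fold higher number from compound 3 to compound 4 (0.88 log units; beyond the scatter).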

Compound 4, half-maximal effective concentration: 4 nM
Estimate against measurement, compound 4: 3.8-fold (0.57 log units) above; measured number inside the range.
By their numbers in this assay, from the lowest: compounds 3, 4 and 1 (each within the scatter of the next, the first and the last beyond it); then compound 2.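

In this assay, the 4-methoxybenzyl group proves dispensable at this place: replacing it with isopropyl removes the aromatic ring and leaves 3 heavy atoms where there were 9, yet the step (a 2.0-fold higher number from compound 3 to compound 4 (0.30 log units; within the scatter)) stays within the scatter, so compound 3 and compound 4 cannot be told apart. The heptyl group can also give way to isopropyl with a step that is within the scatter (a 2.0-fold lower number from compound 1 to compound 4 (0.30 log units; within the scatter)), so neither the long chain nor the ring at its end is required for a low number, while the exchange of the methyl(phenyl)carbamoyl group for isobutoxy on the saturated ring carbon is a step beyond the scatter (an 8.0-fold lower number from compound 2 to compound 4 (0.90 log units; beyond the scatter)) and sets compound 2 apart from compound 4. No measurement at hand accounts for these results.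

On these data alone, whether a still shorter ether such as methoxy, or a free hydroxyl on the saturated ring carbon, would keep the number at this level remains open. So does the effect of an amine or a carboxylic acid at the end of the chain.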